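This account rests on a few compounds, and the source may have more. Where it says the series, first, only, none or still open, it means among the compounds named here.

Three compounds share the core of compound 1 `NNC(=O)c1c(NC(=O)NS(=O)(=O)c2ccccc2)sc2c1CCCCC2` and differ only in the group on the carbonyl carbon that sits on the aromatic carbon of that core. In a functional assay on MCF7 cells (Homo sapiens) for inhibition, with a stated time of 48 h (on this read-out higher numbers stand for weaker inhibition of growth and lower numbers for stronger inhibition of growth), compound 1 gives 4200 nM. Compound 2 `O=C(Nc1sc2c(c1C(=O)NNc1ccccc1)CCCCC2)NS(=O)(=O)c1ccccc1` carries a phenyl on one amine nitrogen of the hydrazide; in this assay compound 2 returns only the limit > 100000 nM. Compound 3 `CN1CCN(C(=O)c2c(NC(=O)NS(=O)(=O)c3ccccc3)sc3c2CCCCC3)CC1` carries a 4-methylpiperazin-1-yl group on the carbonyl carbon; in this assay compound 3 likewise returns only the limit > 100000 nM. Compound 3 thus stands among the weakest values shown, at the limit of > 100000 nM in this assay, at which 2 of the 3 values shown sit.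

Compound 4 `O=C(Nc1sc2c(c1C(=O)NNc1ccc(Br)cc1)CCCCC2)NS(=O)(=O)c1ccccc1` is the next compound, and the change from compound 3 is ((4-bromophenyl)amino)amino in place of 4-methylpiperazin-1-yl on a carbonyl carbon. Within the data shown here, two measured steps bear on this. Measured from the hydrazide, an at least 23-fold higher number from compound 1 to compound 3 (1.37 log units; beyond the scatter) and an at least 23-fold higher number from compound 1 to compound 2 (1.37 log units; beyond the scatter), while a step that the two limits leave unreadable from compound 2 to compound 3. Compound 4 stands closest to compound 2, differing from it only by the bromine of the (4-bromophenyl)amino group, so compound 4 is expected to remain at or near the limit. The step of a number no higher from compound 3 to compound 4 (the limit leaves the size open) is therefore expected to be unreadable or small. For compound 4 the estimate in this assay is 100000 nM, within a range from 15000 nM to 400000 nM.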

Compound 4, concentration for 50% growth inhibition: > 100000 nM
Compound 4 ended at the assay's limit; the forecaster's own chance of this, stated with the estimate: 75%; the middle value sits exactly at the limit.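

In this assay, a 4-bromophenyl on the amine nitrogen of the hydrazide leaves no measured growth inhibition, with an at least 23-fold higher number from compound 1 to compound 4 (1.37 log units; beyond the scatter). Bromine on the phenyl of compound 2 thus brings no return to a measurable value, and compound 4 sits at a limit of the assay, which extends the run of unquantified values on this carbonyl carbon: the limit of > 100000 nM in this assay, at which 3 of the 4 values shown sit. The steps that link compound 4 to compound 2 and compound 3 cannot be read, with limits at both ends.

Among the compounds shown, only the unsubstituted hydrazide of compound 1 gives a number, at 4200 nM, so how far substitution on the amine nitrogen can go stays open, for instance whether a methyl or an acetyl there would keep a measurable value. Also open, as far as these compounds go, is whether any other ring substituent on the phenyl, such as a methoxy or a carboxylic acid, would bring these hydrazides back from the limit, and how far beyond it compound 2, compound 3 and compound 4 actually lie.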